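Restoring a Methoxy Aryl Ether and Adding a Nitro Group

The compounds below may be only part of what the source reports. "The series", "measured", "known", "first", "only" and "open" are said of these compounds alone.

Compound 2 `CC(C)(Oc1ccc(F)cc1)C1OCC(C/C=C\CCC(=O)O)C(c2cccnc2)O1` is the reference point of this small set. Among the compounds with values here, in an assay for inhibition of prostacyclin synthase (Homo sapiens), using microsomes (a lower number here means a stronger inhibitor, a higher number a weaker inhibitor), compound 2 gives 2000 nM, the only measured number among the three values shown. Compound 1 `COc1ccc(OC(C)(C)C2OCC(C/C=C\CCC(=O)O)C(c3cccnc3)O2)cc1` gives > 100000 nM in this assay, which is a limit and not a number. Compound 3 `CC(C)(Oc1ccccc1F)C1OCC(C/C=C\CCC(=O)O)C(c2cccnc2)O1` gives < 1000 nM in this assay, likewise a limit rather than a number. The measured steps show an at least 50-fold lower number from compound 1 to compound 2 (1.69 log units; beyond the scatter) and an at least 100-fold lower number from compound 1 to compound 3 (2.00 log units; beyond the scatter), while an at least 2.0-fold lower number from compound 2 to compound 3 (0.30 log units; that floor lies within the scatter).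

The step considered here leads to compound 4 `COc1ccc(OC(C)(C)C2OCC(C/C=C\CCC(=O)O)C(c3cccnc3)O2)c([N+](=O)[O-])c1`, with 4-methoxy-2-nitrophenyl in place of 4-fluorophenyl on an oxygen on a saturated carbon. This change reverses the exchange seen from compound 1 to compound 2, restoring the methoxy group and adding a nitro group for which no comparison exists in the set. Because an at least 50-fold lower number from compound 1 to compound 2 (1.69 log units; beyond the scatter) was large, the return of the methoxy group is expected to carry a large step in the weaker direction, so compound 4 is expected to show a 20-fold higher number from compound 2 to compound 4 (1.30 log units; beyond the scatter). The nitro group adds uncertainty in both directions. Compound 4 is therefore estimated at 40000 nM in this assay, within a range from 4000 nM to 400000 nM, with a fair chance that only a limit is reported.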

Compound 4, half-maximal inhibitory concentration: 23000 nM
Compound 4: the middle estimate sits 1.7-fold (0.24 log units) above what was measured; measured number inside the range.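

Compound 4 shows that the 4-methoxyphenyl ether can be brought back into a measurable range: in this assay the nitro group in place of hydrogen on an aromatic carbon gives an at least 4.3-fold lower number from compound 1 to compound 4 (0.63 log units; beyond the scatter) on an otherwise unchanged compound. This gain does not reach the level of the fluorinated ethers, for the 4-methoxy-2-nitrophenyl group still gives a 12-fold higher number from compound 2 to compound 4 (1.06 log units; beyond the scatter) and, as a floor only, an at least 23-fold higher number from compound 3 to compound 4 (1.36 log units; beyond the scatter) in the same assay. The gain from the nitro group is also a floor and not a size, because compound 1 stands at a limit: the limit of > 100000 nM in this assay, at which 1 of the 4 values shown sits.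

Going by these compounds, whether a nitro group would move the number in the same way on the 4-fluorophenyl ether of compound 2 or the 2-fluorophenyl ether of compound 3 stays open. So does the question of whether the gain belongs to the nitro group itself or would also come with an amine or a nitrile on that aromatic carbon.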